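The source may hold more compounds than are shown below. What is called first, only, known or untested is meant among the compounds shown, and "the series" means these compounds.

Compound 2 `CCOC(=O)C1=C(N/C=N/c2cccnc2Cl)Nc2[nH]nc(C)c2C1c1ccc(N(C)C)cc1` gives 4890 nM in a functional assay on HepG2 cells (Homo sapiens) for inhibition, read by MTT assay, with a stated time of 48 h (a lower number here means a stronger inhibitor, a higher number a weaker inhibitor), the lowest of the three numbers in hand. Compound 1 `CCOC(=O)C1=C(N/C=N/c2nnc(S(N)(=O)=O)s2)Nc2[nH]nc(C)c2C1c1ccc(N(C)C)cc1` gives 38100 nM and compound 3 `CCOC(=O)C1=C(N/N=C(\c2ccc([N+](=O)[O-])cc2)N2CCN(c3ccc(F)cc3)CC2)Nc2[nH]nc(C)c2C1c1ccc(N(C)C)cc1` gives 90200 nM. Within the data shown here, the one step on the same position is a 7.8-fold lower number from compound 1 to compound 2 (0.89 log units; beyond the scatter), where an aryl group on the double-bonded nitrogen was exchanged. Compound 4 `CCOC(=O)C1=C(N/C=N/c2ccc([N+](=O)[O-])cc2)Nc2[nH]nc(C)c2C1c1ccc(N(C)C)cc1` differs from compound 2 by 4-nitrophenyl in place of 2-chloropyridin-3-yl on a double-bonded nitrogen. Compound 3 also carries a 4-nitrophenyl, but on a different linker, so its number only shows that such compounds can sit far higher. Among the measured compounds shown here, with a single aryl exchange of modest size as the only guide, a step of a 2.5-fold higher number from compound 2 to compound 4 (0.39 log units; beyond the scatter) upward is expected. Compound 4 is estimated at 12000 nM, between 4000 nM and 40000 nM.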

Compound 4, half-maximal inhibitory concentration: 50900 nM
Estimate against measurement, compound 4: 4.2-fold (0.63 log units) below, and the stated range ends below it.
By their numbers in this assay, from the lowest: compound 2; then compounds 1, 4 and 3 (each within the scatter of the next, the first and the last beyond it).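

In this assay the exchange on the double-bonded nitrogen gives a 10-fold higher number from compound 2 to compound 4 (1.02 log units; beyond the scatter) and so is a large step in the upward direction. The other exchange gives a 1.3-fold higher number from compound 1 to compound 4 (0.13 log units; within the scatter) and does not separate 4-nitrophenyl from 5-sulfamoyl-1,3,4-thiadiazol-2-yl, which leaves compound 2 alone at the low end among these three close analogues. Nothing measured here accounts for this change. Going by these compounds, whether the chlorine or the ring nitrogen of 2-chloropyridin-3-yl matters remains open. An unsubstituted phenyl or a pyridin-3-yl without chlorine on the same nitrogen would separate the two.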